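This account rests on a few compounds, and the source may have more. Where it says the series, first, only, none or still open, it means among the compounds named here.

Working notes on the series. Compound 1 `Cc1nc(C(=O)Nc2ccc(Cl)c(-c3nnc4c(Cl)cccn34)c2)cs1` is the reference point for this step. In a functional assay on MCF7 cells (Homo sapiens) for antiproliferative activity, read by MTT assay, with a stated time of 72 h (a lower number here means a stronger inhibitor, a higher number a weaker inhibitor), compound 1 gives > 100000 nM, which is a limit of the assay and not a number. Compound 2 `O=C(Nc1ccc(Cl)c(-c2nnc3c(Cl)cccn23)c1)c1c(F)cccc1Cl` carries a related amide substituent. In this assay compound 2 gives > 100000 nM, again a limit. Among the measured compounds shown here, compound 3 `CS(=O)(=O)c1cccc(C(=O)Nc2ccc(Cl)c(-c3nnc4c(Cl)cccn34)c2)c1` is the only member with a numeric value, and in this assay compound 3 gives 88900 nM. Compound 1 therefore stands at the limit, together with compound 2, as noted in the limit of > 100000 nM in this assay, at which 2 of the 3 values shown sit. The step that the two limits leave unreadable from compound 1 to compound 2 cannot be read, while an at least 1.1-fold lower number from compound 1 to compound 3 (0.05 log units; that floor lies within the scatter) and an at least 1.1-fold lower number from compound 2 to compound 3 (0.05 log units; that floor lies within the scatter) are floors that both lie within the scatter.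

Compound 4 `O=C(Nc1ccc(Cl)c(-c2nnc3c(Cl)cccn23)c1)c1ccccc1Cl` is not yet measured. It differs from compound 1 by 2-chlorophenyl in place of 2-methyl-1,3-thiazol-4-yl on a carbonyl carbon. The nearest measured comparison is compound 2, whose value is a limit. No step beyond the scatter is expected. Compound 4 is expected to sit near the limit, with a step that the limit leaves unreadable from compound 1 to compound 4 and an estimated value of 150000 nM between 50000 nM and 500000 nM.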

Compound 4, half-maximal inhibitory concentration: 92200 nM
For compound 4 the middle estimate is 1.6-fold (0.21 log units) above the measured one; low and high end bracket the measured number.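

In this assay, the swap to 2-chlorophenyl on the carbonyl carbon yields only floors, an at least 1.0-fold lower number from compound 1 to compound 4 (0.03 log units; that floor lies within the scatter) and an at least 1.0-fold lower number from compound 2 to compound 4 (0.03 log units; that floor lies within the scatter), so neither this swap nor hydrogen in place of fluoro on an aromatic carbon shows a step beyond the scatter. Among the compounds shown here, the one step between two numeric values, a 1.0-fold higher number from compound 3 to compound 4 (0.02 log units; within the scatter), shows that 2-chlorophenyl and 3-(methylsulfonyl)phenyl cannot be told apart at this position. The step between the two limits cannot be read, and compound 1 and compound 2 remain at a limit of the assay: the limit of > 100000 nM in this assay, at which 2 of the 4 values shown sit.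

On these data alone, whether any group on this carbonyl carbon can move the number beyond the scatter stays open, for example a piperidine, a carboxylic acid or a longer alkyl chain. As far as these compounds go, all four compounds share the same core, so the effect of a change there is also open.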